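This account rests on a few compounds, and the source may have more. Where it says the series, first, only, none or still open, it means among the compounds named here.

In a physicochemical assay for lipophilicity, read by LC-MS, using the shake flask method, in phosphate buffer, measured as octanol-water partition, with a stated time of 2 h, at pH 7.4 (on this read-out lower numbers stand for lower lipophilicity and higher numbers for higher lipophilicity), compound 1 `O=[N+]([O-])c1ccc(-n2cc(CO[C@H]3O[C@H](CO)[C@@H](O)[C@H](O)[C@@H]3O)nn2)cc1` reads -0.16 and compound 2 `COc1ccc(-n2cc(CO[C@H]3O[C@H](CO)[C@@H](O)[C@H](O)[C@@H]3O)nn2)cc1` reads -0.05 on the same scale. Compound 3 `OC[C@H]1O[C@H](n2cc(-c3cccc(Cl)c3)nn2)[C@@H](O)[C@@H](O)[C@@H]1O` stands highest of the three at 1.22 and lies beyond the scatter from both. Compound 4 `OC[C@H]1O[C@H](n2cc(COc3ccccc3)nn2)[C@@H](O)[C@@H](O)[C@@H]1O` differs from it thus: phenoxymethyl in place of 3-chlorophenyl on an aromatic carbon which amounts to phenoxymethyl in place of 3-chlorophenyl on an aromatic carbon. For the measured compounds named here, the one measured step, a number 0.11 log units higher from compound 1 to compound 2 (within the scatter) here, is a different exchange and stays within the scatter, so it gives no size for this change. Compound 2 at -0.05 also holds a methylene and an ether oxygen in its chain, so a drop is expected in this assay but not the whole gap. The expected move is a number 0.82 log units lower from compound 3 to compound 4 (beyond the scatter) in all. For compound 4 the estimated value is 0.4 with an expected range from -0.1 to 0.9 in this read-out.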

Compound 4, distribution coefficient: -0.18
Beside the measured number, compound 4's estimate is 0.58 log units above it, and the stated range ends above it.
By their numbers in this assay, from the lowest: compounds 4, 1 and 2 (each within the scatter of the next); then compound 3.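

Phenoxymethyl in place of 3-chlorophenyl on this aromatic carbon gives in this assay a large step of a number 1.40 log units lower from compound 3 to compound 4 (beyond the scatter) and shows that this position can shift the read-out. The earlier step of a number 0.11 log units higher from compound 1 to compound 2 (within the scatter) was a different exchange in another place and gave no size for this one. No measured evidence bears on the reason for the size of this step.

Open, going by these compounds, is which part of the exchange carries the step. Also open, on these data alone, is whether an amine, a carboxylic acid or a longer chain on this carbon would read nearer compound 3 or compound 4.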